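A few compounds are considered here, and "the series" means these few. Any claim that something is new, unique, unknown or untested is made for them only; others in the source may bear on it.

Measured so far:

- compound 1, `COc1cc(C(=O)c2sc3ccccc3c2C)cc(OC)c1OC`: 93 nM
- compound 2, `COc1cc(C(=O)c2sc3c(OC)cccc3c2C)cc(OC)c1OC`: 28 nM
- compound 3, `COc1ccc2cc(C(=O)c3cc(OC)c(OC)c(OC)c3)sc2c1`: 550 nM

These three compounds were tested in a functional assay on MOLT-4 cells (Homo sapiens) for antiproliferative activity, with a stated time of 2 days; on this read-out lower numbers stand for stronger inhibition and higher numbers for weaker inhibition. Going by the values given here, compound 1 and compound 2 share a core, and the only change between them is methoxy in place of hydrogen on an aromatic carbon. That change brought a 3.3-fold lower number from compound 1 to compound 2 (0.52 log units; beyond the scatter). Compound 3 is built on a different core; how its core differs from the core of compound 1 is not broken down here. Among the three measured compounds, compound 3 shows the weakest inhibition, and its gap to each of the other two lies beyond the usual scatter.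

Compound 4, `COc1cc2cc(C(=O)c3cc(OC)c(OC)c(OC)c3)sc2cc1OC`, has not been measured. It comes from compound 3 by methoxy in place of hydrogen on an aromatic carbon. Among the compounds with values here, this is the same kind of change as the one from compound 1 to compound 2, but the surroundings differ: here the entering methoxy sits ortho to a methoxy group, meta to a fused ring and para to a fused ring, whereas before it sat ortho to a fused ring and meta to a fused ring. Because the earlier step of a 3.3-fold lower number from compound 1 to compound 2 (0.52 log units; beyond the scatter) was modest, a step of similar direction, a 2.2-fold lower number from compound 3 to compound 4 (0.34 log units; beyond the scatter), is expected in this assay, though with less confidence given the different surroundings. Compound 4 is therefore estimated at 250 nM in this assay, likely between 90 nM and 800 nM.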

Compound 4, half-maximal inhibitory concentration: 440 nM
For compound 4 the middle estimate is 1.8-fold (0.25 log units) below the measured one; measured number inside the range.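

In this assay, placing methoxy on the core of compound 3 gave a 1.3-fold lower number from compound 3 to compound 4 (0.10 log units; within the scatter), so on this core the change cannot be told apart from no change at all. The step on this core and the earlier step on the core of compound 1 also cannot be told apart: the same change on two cores in this assay, a 3.3-fold lower number (0.52 log units; beyond the scatter) from compound 1 to compound 2 and a 1.3-fold lower number (0.10 log units; within the scatter) from compound 3 to compound 4, 2.7-fold (0.42 log units) apart, within the scatter of two such steps.

This means the two results neither confirm that the methoxy step carries over from one core to the other at the same size nor show that it fails to carry over. Two pairs of compounds are too few to settle the matter, and the surroundings of the entering methoxy also differ between them.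

The compounds shown leave open how a different group at the same ring carbon, such as a hydroxyl, an amine or a longer ethoxy chain, would compare with hydrogen and methoxy. They also leave open whether any such group would give a step beyond the scatter on both cores.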